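The source may hold more compounds than are shown below. What is called first, only, known or untested is meant among the compounds shown, and "the series" means these compounds.

Compound 1 `CCC(/C=C(\COC(C)=O)C(=O)c1ccccc1)CC` gives 50000 nM in a functional assay on HeLa cells (Homo sapiens) for inhibition, read by sulforhodamine B assay, with a stated time of 48 h; a lower number here means a stronger inhibitor of growth, a higher number a weaker inhibitor of growth. Compound 2 `CC(=O)OC/C(=C\c1ccc(Cl)cc1)C(=O)c1ccccc1` gives 3200 nM in this assay. Compound 3 `CC(=O)OC/C(=C\c1ccc(F)cc1)C(=O)c1ccccc1` gives 25000 nM in this assay.

Compound 2 has the lowest number of the three measured compounds. Its nearest neighbour is compound 3, separated by a 7.8-fold higher number from compound 2 to compound 3 (0.89 log units; beyond the scatter), and the furthest is compound 1, separated by a 16-fold lower number from compound 1 to compound 2 (1.19 log units; beyond the scatter). Both of these steps sit beyond the scatter.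

Compound 4 `CC(=O)OC/C(=C\c1ccc(Cl)cc1)C(=O)c1ccc(Cl)cc1` differs from compound 2 by chloro in place of hydrogen on an aromatic carbon. This change sits on the phenyl bound to the carbonyl, the ring that all three measured compounds keep unchanged. Among the measured compounds shown here, no measured step places a substituent on that ring. For the measured compounds named here, the steps that bear on the change are the two that concern chloro on the other aromatic ring: the large 16-fold lower number from compound 1 to compound 2 (1.19 log units; beyond the scatter) and the modest 7.8-fold higher number from compound 2 to compound 3 (0.89 log units; beyond the scatter), both showing that this assay responds clearly to a chloro on an aromatic ring. Going by these compounds, whether the carbonyl-side ring behaves the same is untested, so only a small step of a 1.5-fold lower number from compound 2 to compound 4 (0.16 log units; within the scatter) is expected, leaning toward a lower number, with a wide range. Compound 4 is therefore expected to give about 2200 nM, between 700 nM and 7000 nM.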

Compound 4, concentration for 50% growth inhibition: 19000 nM
Beside the measured number, compound 4's estimate is 8.6-fold (0.94 log units) below it, and the stated range ends below it.
By their numbers in this assay, from the lowest: compound 2; then compounds 4, 3 and 1 (each within the scatter of the next, the first and the last beyond it).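

In this assay, the change from phenyl to 4-chlorophenyl gives a 5.9-fold higher number from compound 2 to compound 4 (0.77 log units; beyond the scatter), so this ring, which stays unsubstituted in compound 1, compound 2 and compound 3, is a place where the assay responds to a substituent. The chloro on the other aromatic ring of compound 2 comes with the lowest number of the series, yet a second chloro on this ring makes a weaker inhibitor of growth, so a chloro does not act in the same direction on both rings. Nothing given here accounts for this rise in the number.

The compounds shown leave open whether the rise belongs to chloro itself or to any group at this place, since only hydrogen and chloro have been compared there, and a fluoro, a methoxy group or an amine on the same aromatic carbon could read differently. They also leave open whether the same change would run the same way with 4-fluorophenyl or pentan-3-yl on the double-bonded chain carbon, as in compound 3 and compound 1.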